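Trimming the Ring Nitrogen Substituent from Ethyl to Methyl

The compounds below may be only part of what the source reports. "The series", "measured", "known", "first", "only" and "open" are said of these compounds alone.

Compound 1, `Cn1nc(CN2CCCC2)nc1-c1cccc(Oc2ccccc2)c1`, gives > 1000 nM in an assay on membranes from Jurkat cells for displacement of a labelled ligand from Sigma intracellular receptor 2 (Homo sapiens), read by scintillation counting, with a stated time of 1 h; a higher number here means a weaker inhibitor, a lower number a stronger inhibitor; this is a limit of the assay, not a number.
Compound 2, `CCn1nc(CN2CCCC2)nc1-c1ccc(C(C)(C)C)cc1`, gives 1710 nM in this assay.
Compound 3, `Cn1nc(CN2CCCC2)nc1-c1ccc(Cl)c(Cl)c1`, gives > 1000 nM in this assay; this too is a limit, not a number.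

For the measured compounds named here, compound 2 is the only compound with a number rather than a limit, and that number marks a weak inhibitor. Compound 4, `Cn1nc(CN2CCCC2)nc1-c1ccc(C(C)(C)C)cc1`, has not been measured. It differs from compound 2 by hydrogen in place of methyl on a saturated chain carbon bound to an aromatic nitrogen. Going by the values given here, no measured pair shows this change alone, so its size cannot be read from the data. In this assay the expected step is small, within the scatter, with no clear direction. Compound 4 is estimated at 2000 nM, between 800 nM and 5000 nM. The estimated step is a 1.2-fold higher number from compound 2 to compound 4 (0.07 log units; within the scatter).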

Compound 4, inhibition constant: > 1000 nM
Compound 4 ended at the assay's limit; the forecaster's own chance of this, stated with the estimate: 40%; the middle value does not contradict the limit.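

The step from compound 2 to compound 4 cannot be read, because compound 4 gives a limit of the assay, not a number: the limit of > 1000 nM in this assay, at which 3 of the 4 values shown sit. The compounds shown leave open what the change from ethyl to methyl does in this assay.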